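Dropping a Fluorine from a Quinazoline-Type Core

This account rests on a few compounds, and the source may have more. Where it says the series, first, only, none or still open, it means among the compounds named here.

Compound 1 `CN(C)CCCNc1nc(NCc2ccco2)c2ccccc2n1`: "not determined" (no result reported)
Compound 2 `CCCCNc1nc(NCc2ccco2)c2cccc(F)c2n1`: 2630 nM

Among the measured compounds shown here, compound 2 carries the only number reported; for compound 1 the entry reads "not determined" (no result reported). In a functional assay on A375P cells (Homo sapiens) for cytotoxicity, read by MTT assay, with a stated time of 2 days (a higher number here means a weaker inhibitor, a lower number a stronger inhibitor), compound 2 gives 2630 nM. Compound 3 `CCCCNc1nc(NCc2ccco2)c2ccccc2n1` differs from compound 2 in one place: hydrogen in place of fluoro on an aromatic carbon. For the measured compounds named here, no pair of measured compounds shows how such a change shifts this assay, so the step is expected to stay within the usual scatter, with no clear direction. Compound 3 is therefore estimated at 2600 nM, between 1000 nM and 7000 nM, a step of a 1.0-fold lower number from compound 2 to compound 3 (0.00 log units; within the scatter) from its parent.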

Compound 3, half-maximal inhibitory concentration: 9200 nM
The estimate for compound 3 lay 3.5-fold (0.55 log units) below the measured number; the measured number lies above the stated range.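

In this assay, putting hydrogen in place of fluoro on this aromatic carbon gives a 3.5-fold higher number from compound 2 to compound 3 (0.54 log units; beyond the scatter) and nothing smaller than the usual scatter, so this position is not indifferent to the change. Here the compound keeping fluoro has the lower number, meaning the stronger inhibitor of the two. No measurement at hand explains this shift. On these data alone, whether a chlorine atom or a methoxy group on the same carbon would lower or raise the number stays open. Compound 1, with its different chain, offers no number, so the effect of that chain cannot be read.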